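The compounds below may be only part of what the source reports. "The series", "measured", "known", "first", "only" and "open" are said of these compounds alone.

Measured so far in a functional assay on U-87MG ATCC cells (Homo sapiens) for antiproliferative activity; a lower number here means a stronger inhibitor, a higher number a weaker inhibitor:
- compound 1 `Cc1c2c(n3c1CCCN[C@@H](C)[C@H](C)Nc1cc-3ccc1C(N)=O)CC(C)(C)CC2=O` gives 61 nM
- compound 2 `CC(=O)N1CCCc2c(C)c3c(n2-c2ccc(C(N)=O)c(c2)N[C@@H](C)[C@@H]1C)CC(C)(C)CC3=O` gives 29 nM
- compound 3 `CC(=O)N1CCc2c(C)c3c(n2-c2ccc(C(N)=O)c(c2)N[C@@H](C)[C@H](C)C1)CC(C)(C)CC3=O` gives 24 nM

Compound 2 lies within the usual scatter of compound 3, and its number is clearly lower than that of compound 1. The next structure is compound 4 `COCCC(=O)N1CCCc2c(C)c3c(n2-c2ccc(C(N)=O)c(c2)N[C@@H](C)[C@@H]1C)CC(C)(C)CC3=O` which differs from compound 2 in a single place: methoxymethyl in place of hydrogen on a saturated chain carbon bound to a carbonyl carbon in words, methoxymethyl in place of hydrogen on a saturated chain carbon bound to a carbonyl carbon. Put another way, acetyl becomes (2-methoxyethyl)carbonyl.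

For the measured compounds named here, one measured step bears on this part of the molecule: a 2.1-fold lower number from compound 1 to compound 2 (0.32 log units; beyond the scatter) came with acetyl in place of hydrogen on an amine nitrogen in a ring. That step was modest, though beyond the scatter, and it introduced the acetyl that is now extended. Going by the values given here, no measured pair shows what extending this group does, so no step beyond the scatter is expected in this assay in either direction. The estimated move is a 1.1-fold higher number from compound 2 to compound 4 (0.04 log units; within the scatter) and no more. Compound 4 is expected at 32 nM within an estimated range of 12 nM to 85 nM for repeated measurements.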

Compound 4, half-maximal inhibitory concentration: 80 nM
Estimate against measurement, compound 4: 2.5-fold (0.40 log units) below; low and high end bracket the measured number.
By their numbers in this assay, from the lowest: compounds 3 and 2 (each within the scatter of the next); then compounds 1 and 4 (each within the scatter of the next).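

In this assay, this position does not accept every extension of the acetyl group: methoxymethyl in place of hydrogen on the saturated chain carbon bound to the carbonyl carbon gives a 2.8-fold higher number from compound 2 to compound 4 (0.44 log units; beyond the scatter), a modest but real loss of strength. The benefit seen with acetyl on the ring amine nitrogen does not carry over to the (2-methoxyethyl)carbonyl group, which gives a 1.3-fold higher number from compound 1 to compound 4 (0.12 log units; within the scatter), so compound 4 stands level with the compound that has only hydrogen on that nitrogen. Nothing shown here gives a reason for this loss.

The compounds shown cannot separate the effect of chain length from that of the ether oxygen, as none carries a plain butanoyl group on this nitrogen. From the compounds shown here alone, how an amine or a carboxylic acid at the end of this chain would behave also remains open.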